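Aromatic substituents in a small cytotoxicity series

The source may hold more compounds than are shown below. What is called first, only, known or untested is meant among the compounds shown, and "the series" means these compounds.

Measured compounds:
compound 1: `C/C(=C\c1cc(-c2ccc(F)cc2)co1)C(N)=O`, > 50000 nM
compound 2: `C/C(=C\c1cc(-c2ccccc2)cs1)C(N)=O`, > 50000 nM
compound 3: `C/C(=C\c1cc(-c2ccccc2C)cs1)C(N)=O`, 15200 nM

Notes. In a functional assay on HO8910 cells (Homo sapiens) for cytotoxicity, read by CCK-8 assay, with a stated time of 24 h (on this read-out higher numbers stand for weaker inhibition and lower numbers for stronger inhibition), compound 2 gives > 50000 nM, which is a limit of the assay and not a number. Compound 2 thus stands at the limit of > 50000 nM in this assay, at which 2 of the 3 values shown sit. Compound 1 gives > 50000 nM, likewise a limit. Among the compounds with values here, compound 3 is the only compound with a number, 15200 nM.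

Compound 4, `COc1ccc(-c2csc(/C=C(\C)C(N)=O)c2)cc1`, differs from compound 2 by methoxy in place of hydrogen on an aromatic carbon. Within the data shown here, the one measured step that bears on it is an at least 3.2-fold lower number from compound 2 to compound 3 (0.51 log units; beyond the scatter), a substituent added to the same six-membered ring, though at a different carbon and with a different group. Among the measured compounds shown here, that step is the sole guide here, and the starting point is a limit, so the true size of any change from compound 2 is unknown.

The expectation for compound 4 is a step of an at least 1.6-fold lower number from compound 2 to compound 4 (0.22 log units; that floor lies within the scatter) in this assay, toward a lower number, with a real chance that the result is again only a limit. Compound 4 is estimated at 30000 nM, in the range 8000 nM to 60000 nM.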

Compound 4, half-maximal inhibitory concentration: > 50000 nM
Compound 4: a limit, no number; the forecaster's own chance of this, stated with the estimate: 40%; middle value at least 1.6-fold (0.22 log units) away from the limit.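

In this assay compound 4 gives > 50000 nM, a limit and not a number. Compound 2 also stands at a limit, and the step from compound 2 to compound 4 cannot be read. The compounds shown leave open whether methoxy in place of hydrogen changes the read-out at all.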